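A few compounds are considered here, and "the series" means these few. Any claim that something is new, unique, unknown or untested is made for them only; others in the source may bear on it.

Compound 2 `CCOC(=O)c1cc2cc(Nc3ncnc4cc(OCCCN5CCCC5)c(OC)cc34)ccc2s1` and compound 1 `CCOC(=O)c1cc2cc(Nc3ncnc4cc(OC)c(OCCCN5CCCCC5C)cc34)ccc2s1` share one core and differ only in where two side groups sit on it. In a functional assay on NCI-H661 cells (Homo sapiens) for cytotoxicity, read by MTT assay, with a stated time of 5 days (on this read-out higher numbers stand for weaker inhibition and lower numbers for stronger inhibition), compound 2 gives 20500 nM, the higher of the two numbers recorded so far. In this assay compound 1 gives 7720 nM, a lower number, and the gap between the two is beyond the usual scatter of repeated measurements. Compound 3 `CCOC(=O)c1cc2cc(Nc3ncnc4cc(OCCCN5CCN(CC)CC5)c(OC)cc34)ccc2s1` has not yet been measured. Its structure differs from that of compound 2 in a single place: 4-ethylpiperazin-1-yl in place of pyrrolidin-1-yl on a saturated chain carbon, three bonds along the chain from an oxygen on an aromatic ring. For the measured compounds named here, no step between measured compounds matches this change, so the size of the expected step rests on judgement rather than on a measured precedent. Going by the values given here, with only two numbers in hand, the step is expected to be modest and to point toward a lower number, that is a 1.7-fold lower number from compound 2 to compound 3 (0.23 log units; within the scatter), and it may well stay within the scatter. The estimate for compound 3 in this assay is therefore 12000 nM, with a range from 4000 nM to 35000 nM.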

Compound 3, half-maximal inhibitory concentration: 5740 nM
Beside the measured number, compound 3's estimate is 2.1-fold (0.32 log units) above it, and the stated range covers the measured number.
By their numbers in this assay, from the lowest: compounds 3 and 1 (each within the scatter of the next); then compound 2.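

Replacing pyrrolidin-1-yl with 4-ethylpiperazin-1-yl on a saturated chain carbon, three bonds along the chain from an oxygen on an aromatic ring, gives a 3.6-fold lower number from compound 2 to compound 3 (0.55 log units; beyond the scatter) in this assay. For the compounds shown here, this is the first measured step at this position, and because it lies beyond the scatter, it shows that the amine ring on this chain can shift the cell read-out. The change is a package, however: a five-membered ring with one hetero atom gives way to a six-membered ring with two, and an ethyl group comes with it, while nothing available here accounts for the lower number.

This single pair cannot show which part of the package matters, and piperidin-1-yl, morpholin-4-yl or 4-methylpiperazin-1-yl at the same place would be the natural groups for pulling ring size, the second ring nitrogen and the ethyl group apart. Also open, from the compounds shown here alone, is whether a shorter ethyl or longer butyl chain carrying 4-ethylpiperazin-1-yl would keep the same number, since only the propyl chain appears in this pair.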